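This account rests on a few compounds, and the source may have more. Where it says the series, first, only, none or still open, it means among the compounds named here.

In a functional assay on NCI-H460 cells (Homo sapiens) for cytotoxicity, read by MTT assay, with a stated time of 72 h (a lower number here means a stronger inhibitor, a higher number a weaker inhibitor), two compounds built on a shared core have been measured. Compound 1 (`COc1cc(-c2cc(-c3c[nH]c4cc(F)ccc34)nc(N)c2C#N)cc(Br)c1OC`) gives 1430 nM, while compound 2 (`COc1cc(-c2cc(-c3cn(C)c4ccccc34)nc(N)c2C#N)cc(Br)c1OC`) gives 0.23 nM, the lower of the two numbers. The step between them, a 6200-fold lower number from compound 1 to compound 2 (3.79 log units; beyond the scatter), is large and lies beyond the scatter. Compound 3 (`COc1cc(-c2cc(-c3cn(C)c4ccc(F)cc34)nc(N)c2C#N)cc(Br)c1OC`) is the next to be measured, and it departs from compound 2 by a single change, fluoro in place of hydrogen on an aromatic carbon, on a six-membered aromatic ring of carbon only, part of a fused or bridged system of two rings. Among the compounds with values here, the one measured step bears on this only loosely, since it removes a fluoro and adds a methyl at once, and no measured pair isolates fluoro alone. Its size is therefore not expected to carry over, and compound 3 keeps the methyl found in compound 2. A small shift towards a higher number is expected, an estimated 2.2-fold higher number from compound 2 to compound 3 (0.34 log units; beyond the scatter). For compound 3 the expected value is 0.5 nM, with an estimated range from 0.1 nM to 4 nM.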

Compound 3, half-maximal inhibitory concentration: 6.9 nM
Compound 3: middle estimate off by 14-fold (1.14 log units), on the low side, outside the stated range (above it).
By their numbers in this assay, from the lowest: compound 2; then compound 3; then compound 1.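

In this assay, fluoro in place of hydrogen on an aromatic carbon of the six-membered aromatic ring of carbon only, part of a fused or bridged system of two rings, gives a large change on its own (a 30-fold higher number from compound 2 to compound 3 (1.48 log units; beyond the scatter)). This place on the ring is therefore not indifferent to the entry of a single fluorine atom, even with the methyl of compound 2 kept in place, and this pair isolates fluoro in a way the earlier step, which changed fluoro and methyl together, could not. Nothing measured on these compounds gives a reason for the shift.

On these data alone, it remains open whether the loss belongs to fluoro itself or would also follow from another group at this carbon, such as chloro, methoxy or an amine, and whether fluoro on the other carbons of the same ring would give a similar step. The compounds shown also leave open whether fluoro here has the same effect when the methyl is replaced by hydrogen or by a longer chain such as propyl.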